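Piperidine amide replacing oxolanyl amide in compound 2

This account rests on a few compounds, and the source may have more. Where it says the series, first, only, none or still open, it means among the compounds named here.

Measured so far:
compound 1 `O=C([C@@H]1CCCN(S(=O)(=O)c2ccc(S(=O)(=O)N3CC[C@@H](O)C3)cc2)C1)N1CCC(F)(F)CC1` — 135 nM
compound 2 `CCN(CC)S(=O)(=O)c1ccc(S(=O)(=O)N2CCC[C@@H](C(=O)N[C@H]3CCOC3)C2)cc1` — 290 nM

Both compounds have been run in a functional assay on MIA PaCa-2 cells (Homo sapiens) for inhibition, read by MTT assay, with a stated time of 3 days; on this read-out lower numbers stand for stronger inhibition and higher numbers for weaker inhibition. Compound 2 stands at the higher of the two numbers, with 290 nM; its nearest neighbour is compound 1 at 135 nM, and that gap is wider than the usual scatter. Compound 1 and compound 2 differ in more than one place, so no single step can be read from them.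

Compound 3 `CCN(CC)S(=O)(=O)c1ccc(S(=O)(=O)N2CCC[C@@H](C(=O)N3CCC(C(F)F)CC3)C2)cc1` is the next point. It differs from compound 2 at one site: 4-(difluoromethyl)piperidin-1-yl in place of (oxolan-3-yl)amino on a carbonyl carbon. The entering group carries no hydrogen-bond donor and no acceptor where the leaving group carried one of each.

For the measured compounds named here, no measured step of this kind exists in the set, so the size of the change is uncertain. On the pair shown, the expectation is a modest move toward a lower number, of the order of a 1.8-fold lower number from compound 2 to compound 3 (0.26 log units; within the scatter), and not clearly beyond the scatter. Compound 3 is therefore estimated at 160 nM, within a range of 60 nM to 450 nM.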

Compound 3, half-maximal inhibitory concentration: 140 nM
Estimate against measurement, compound 3: 1.1-fold (0.06 log units) above; low and high end bracket the measured number.
By their numbers in this assay, from the lowest: compounds 1 and 3 (each within the scatter of the next); then compound 2.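

In this assay, for the compounds shown here, the step on the carbonyl carbon is the first that can be read at a single place: 4-(difluoromethyl)piperidin-1-yl in place of (oxolan-3-yl)amino gives a 2.1-fold lower number from compound 2 to compound 3 (0.32 log units; beyond the scatter) and is the only measured change at this position. The hydrogen-bond donor and acceptor counted on (oxolan-3-yl)amino are therefore not required here for a number at this level, since the entering group carries neither and the number falls rather than rises. The step changes the ring, the donor and acceptor counts and the fluorine content together, and nothing measured on these compounds separates these changes or explains the shift.

Going by these compounds, it remains open whether the lower number belongs to the difluoromethyl group or to the piperidine ring alone, a question that unsubstituted piperidin-1-yl at the same place would address. On these data alone, it also remains open whether cyclohexylamino, which keeps the amide hydrogen while dropping the ring oxygen, would stand with compound 2 or with compound 3.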